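The compounds below may be only part of what the source reports. "The series", "measured", "known", "first", "only" and "open" are said of these compounds alone.

Four related compounds are compared for how strongly they inhibit the growth of a human lung cancer cell line, measured in a functional assay on A549 cells (Homo sapiens) for cytotoxicity, read by MTT assay, with a stated time of 48 h; on this read-out lower numbers stand for stronger inhibition and higher numbers for weaker inhibition. Compound 3 `CN(C)CCCCCSC1=Nc2ccccc2C(CC(=O)NCc2ccc(F)cc2)N1c1ccc(-c2ccc(F)cc2)cc1` gives 11300 nM in this assay. Compound 1 `O=C(CC1c2ccccc2N=C(SCCCCCN2CCCC2)N1c1ccc(-c2ccc(F)cc2)cc1)NCc1ccc(F)cc1` differs from compound 3 by one change, (pyrrolidin-1-yl in place of dimethylamino on a saturated chain carbon, five bonds along the chain from a sulfur), and in this assay compound 1 gives 12600 nM. This change produced a 1.1-fold higher number from compound 3 to compound 1 (0.05 log units; within the scatter), so the two numbers are treated as equal within the usual scatter of the assay.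

Compound 2 `CN(C)CCCCCSC1=Nc2ccccc2C(CC(=O)NCc2ccccc2)N1c1ccccc1` has a different core, and the difference between its core and that of compound 3 is not broken down here. In this assay compound 2 gives 138000 nM, the highest of the three numbers, and its gap from compound 1 lies beyond the scatter. Compound 4 `O=C(CC1c2ccccc2N=C(SCCCCCN2CCCC2)N1c1ccccc1)NCc1ccccc1` has not yet been measured; it differs from compound 2 by pyrrolidin-1-yl in place of dimethylamino on a saturated chain carbon, five bonds along the chain from a sulfur, the same change seen between compound 3 and compound 1. Because the earlier step was a 1.1-fold higher number from compound 3 to compound 1 (0.05 log units; within the scatter), a step of about a 1.0-fold higher number from compound 2 to compound 4 (0.01 log units; within the scatter) is expected from compound 2 to compound 4 in this assay. Compound 4 is therefore estimated at 140000 nM, expected to fall between 60000 nM and 320000 nM.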

Compound 4, half-maximal inhibitory concentration: 98100 nM
The estimate for compound 4 lay 1.4-fold (0.15 log units) above the measured number; the range from low to high includes it.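

On the second core, putting pyrrolidin-1-yl in place of dimethylamino gives a 1.4-fold lower number from compound 2 to compound 4 (0.15 log units; within the scatter), so the two numbers count as equal within the usual scatter. Set side by side, the steps on the two cores do not differ: the same change on two cores in this assay, a 1.1-fold higher number (0.05 log units; within the scatter) from compound 3 to compound 1 and a 1.4-fold lower number (0.15 log units; within the scatter) from compound 2 to compound 4, 1.6-fold (0.20 log units) apart, within the scatter of two such steps

On these two cores, then, the swap carries over in this assay, with neither core separating the two amines, but two pairs make no general rule and say nothing about other cores or other assays.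

The compounds shown leave open whether another cyclic amine on the same chain, such as piperidine or morpholine, or a shorter or longer chain between the sulfur and the amine, would give similar numbers. They also leave open which of the differences between the core of compound 2 and the core of compound 3 goes with the gap between their numbers.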